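The source may report more compounds than this note shows. Statements on the series, on what has been measured and on what is new or still open speak of the compounds shown alone.

Compound 1 `CS(=O)(=O)c1ccc(-c2cnc3[nH]cc(-c4nnc(-c5ccncc5)o4)c(=O)c3c2)cc1`: in a functional assay on KB cells (Homo sapiens) for inhibition, read by MTT assay, with a stated time of 24 h, tested at 10 uM (a lower number here means less inhibition of growth, a higher number more inhibition of growth at the concentration tested), compound 1 gives 3.02%.
Compound 2 `CS(=O)(=O)c1ccc(-c2cnc3[nH]cc(-c4nnc(-c5ccc(Cl)cc5)o4)c(=O)c3c2)cc1`: in this assay compound 2 gives 9.3%.

Both compounds share the same core and differ only in the aromatic ring attached to the five-membered ring: the step from compound 1 to compound 2, 4-chlorophenyl in place of pyridin-4-yl on an aromatic carbon, gives a number 6.3 percentage points higher from compound 1 to compound 2 (within the scatter). Compound 2 thus has the higher of the two numbers, but its gap to compound 1 lies within the scatter, so the two are not told apart.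

Compound 3 `Cc1ccc(-c2nnc(-c3c[nH]c4ncc(-c5ccc(S(C)(=O)=O)cc5)cc4c3=O)o2)cc1` is not yet measured in this assay. It differs from compound 2 by methyl in place of chloro on an aromatic carbon. Going by the values given here, the only measured step, on the same ring, changed the number within the scatter, so for this small swap no movement beyond the scatter is expected either: the estimated step is a number 1.3 percentage points lower from compound 2 to compound 3 (within the scatter). Compound 3 is therefore expected to give about 8%, with a range from 0% to 20%.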

Compound 3, percent growth inhibition at one concentration: 3.19%
For compound 3 the middle estimate is 4.8 percentage points above the measured one; the measured number falls inside the stated range.
By their numbers in this assay, from the lowest: compounds 1, 3 and 2 (each within the scatter of the next).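

At this position, para to a large group on the ring of carbon only, methyl in place of chloro gives a number 6.1 percentage points lower from compound 2 to compound 3 (within the scatter) in this assay, so these two single-atom groups cannot be told apart here. Replacing pyridin-4-yl with 4-methylphenyl gives a number 0.2 percentage points higher from compound 1 to compound 3 (within the scatter), so this ring swap, like the 4-chlorophenyl swap before it, does not separate the compounds. Nothing available bears on these results, so no explanation can be offered.

From the compounds shown here alone, it remains open whether an amine, a carboxylic acid or a longer chain at this same position would move the number beyond the scatter. Also open, going by these compounds, is whether these three compounds, which cannot be told apart at the single concentration tested, would separate at higher concentrations.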